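Shared-core series: from compound 2 to compound 4

The compounds below may be only part of what the source reports. "The series", "measured", "known", "first", "only" and "open" are said of these compounds alone.

Three measured compounds share one core. In a physicochemical assay for lipophilicity, measured as octanol-water partition (on this read-out higher numbers stand for higher lipophilicity and lower numbers for lower lipophilicity), compound 1 `O=C(COc1cccc2ccccc12)N/N=C/c1c(O)ccc2ccccc12` gives 4.74, compound 3 `C/C(=N\NC(=O)COc1cccc2ccccc12)c1ccc(O)cc1O` gives 4.31, and compound 2 `O=C(COc1cccc2ccccc12)N/N=C/c1ccccc1Br` gives 4.81, the highest of the three numbers. Compound 2 and compound 1 lie within the scatter of each other, while compound 3 sits below compound 2 by a gap beyond the scatter. Compound 4 `O=C(COc1cccc2ccccc12)N/N=C/c1ccccc1` is not yet measured. It differs from compound 2 by hydrogen in place of bromo on an aromatic carbon. Among the measured compounds shown here, no step between measured compounds covers this change, so the expectation rests on the change alone. The step this estimate means, a number 0.86 log units lower from compound 2 to compound 4 (beyond the scatter), is expected to be downward and beyond the scatter. In this assay compound 4 is expected to give 3.95, with a range from 3.5 to 4.4.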

Compound 4, partition coefficient: 4.02
Beside the measured number, compound 4's estimate is 0.07 log units below it; the range from low to high includes it.
By their numbers in this assay, from the lowest: compounds 4 and 3 (each within the scatter of the next); then compounds 1 and 2 (each within the scatter of the next).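

Hydrogen in place of bromo on this aromatic carbon, ortho to a large group, gives the first one-place step of the series in this assay, a number 0.79 log units lower from compound 2 to compound 4 (beyond the scatter). The position therefore registers on this read-out, and the 2-bromophenyl to phenyl change alone is enough to produce a step beyond the scatter. Nothing available accounts for the size of this step.

As far as these compounds go, whether a methoxy group, an amine or a carboxylic acid on this carbon would move the number as far remains open. Also open, from the compounds shown here alone, is whether the same change gives a like step on another compound of the series.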